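One More Carbon on the Chain of Compound 2

A few compounds are considered here, and "the series" means these few. Any claim that something is new, unique, unknown or untested is made for them only; others in the source may bear on it.

In an ADME assay on HepG2 cells (Homo sapiens) for cytotoxicity, read by MTT assay, with a stated time of 72 h (a lower number here means that less compound is tolerated, a higher number that more compound is tolerated), compound 1 `CCCNc1nc2cc(-c3ccc(C)cc3)sc2c(=O)[nH]1` gives > 62500 nM, which is a limit of the assay and not a number.

Among the compounds with values here, compound 2 `CCCCCNc1nc2cc(-c3ccc(C)cc3)sc2c(=O)[nH]1` gives 4200 nM, the only actual number so far. Compound 3 `CCCCCCNc1nc2cc(-c3ccc(C)cc3)sc2c(=O)[nH]1` has not yet been measured. It differs from compound 2 as follows: methyl in place of hydrogen on a saturated chain carbon, five bonds along the chain from a nitrogen on an aromatic ring. In words, this is methyl in place of hydrogen on a saturated chain carbon, five bonds along the chain from a nitrogen on an aromatic ring.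

Within the data shown here, one measured step bears on this change, and it lies on the same chain: an at least 14-fold lower number from compound 1 to compound 2 (1.17 log units; beyond the scatter). That step was large, but it added ethyl, whereas the new change adds only methyl. It is also a single step, so it offers a direction and no firm slope.

A smaller move in the same direction is therefore expected, towards less compound being tolerated, and the expected step is a 2.3-fold lower number from compound 2 to compound 3 (0.37 log units; beyond the scatter). For compound 3 the estimated value in this assay is 1800 nM, with an expected range from 600 nM to 5000 nM.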

Compound 3, half-maximal cytotoxic concentration: 10600 nM
Estimate against measurement, compound 3: 5.9-fold (0.77 log units) below; measured number above the stated range.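

In this assay, the earlier step showed only a fall in the number as the chain grew, but the added methyl at this position reverses that direction, with a 2.5-fold higher number from compound 2 to compound 3 (0.40 log units; beyond the scatter), a modest change that lies beyond the scatter. The longer chain does not return to the level of the shortest one, with an at least 5.8-fold lower number from compound 1 to compound 3 (0.77 log units; beyond the scatter), so among these three compounds the lowest number belongs to compound 2 and not to the compound with the longest chain. The true size of the steps that start from compound 1 remains unknown because its value is a limit of the assay and not a number: the limit of > 62500 nM in this assay, at which 1 of the 3 values shown sits.

The compounds shown leave open whether a still longer chain would continue the rise in the number seen with compound 3, or whether a branched chain or a chain ending in an amine or a carboxylic acid would follow the same course. They also leave open whether this turn in the series would persist if another group replaced the methyl on the shared core.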